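Compound 3: a step no measured pair covers

A few compounds are considered here, and "the series" means these few. Any claim that something is new, unique, unknown or untested is made for them only; others in the source may bear on it.

Values in a functional assay on THP-1 cells (Homo sapiens) for inhibition (a higher number here means a weaker inhibitor of growth, a lower number a stronger inhibitor of growth), for the compounds so far
Compound 1 `Cc1noc(C)c1-c1ccc2c(c1)c(CCc1ccccc1)cn2CCCCCC(=O)NO` gives 15500 nM
Compound 2 `Cc1noc(C)c1-c1ccc2c(c1)c(CCc1ccc(F)cc1)cn2CCCCCC(=O)NO` gives 15500 nM
Compound 3 `Cc1ccccc1Cc1cn(CCCCCC(=O)NO)c2ccc(-c3c(C)noc3C)cc12` awaits measurement

Compound 2 stands level with compound 1 on these numbers. The next change is 2-methylphenyl in place of 4-fluorobenzyl on a saturated chain carbon bound to an aromatic carbon. Cut one bond further out, it reads 2-(4-fluorophenyl)ethyl to 2-methylbenzyl. Going by the values given here, the only measured step shows no change at the digits printed from compound 1 to compound 2 (within the scatter) for fluoro in place of hydrogen on an aromatic carbon, and no measured step covers the rest of the change. In this assay no direction is therefore expected, and the estimate is a 1.2-fold lower number from compound 2 to compound 3 (0.08 log units; within the scatter) (none beyond the scatter). For compound 3 the expected value is 13000 nM (estimated range 5000 nM to 30000 nM).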

Compound 3, concentration for 50% growth inhibition: 15500 nM
Compound 3: middle estimate off by 1.2-fold (0.08 log units), on the low side; the range from low to high includes it.
By their numbers in this assay, from the lowest: compounds 1, 2 and 3 (each within the scatter of the next).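

In this assay, 2-methylphenyl in place of 4-fluorobenzyl gives no change at the digits printed from compound 2 to compound 3 (within the scatter), and 2-methylphenyl in place of benzyl gives no change at the digits printed from compound 1 to compound 3 (within the scatter). The earlier pair differed only by a fluoro in place of hydrogen on an aromatic carbon, whereas these steps replace the group on the saturated chain carbon bound to an aromatic carbon, and still no difference appears. The compounds shown leave open whether an amine or a carboxylic acid at this place would separate from these three in this assay. Nothing else available bears on this result.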